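This account rests on a few compounds, and the source may have more. Where it says the series, first, only, none or still open, it means among the compounds named here.

Compound 2 `Fc1cc(C(F)(F)F)cc(C(F)(F)F)c1` sits in an ADME assay for pharmacokinetics, read by LC-MS, in phosphate buffer, with a stated time of 72 h, at pH 7.4, tested at 250 uM (on this read-out lower numbers stand for a shorter-lived compound and higher numbers for a longer-lived compound), at a limit of the assay rather than at a number, > 50 h. Compound 1 `N#Cc1cc(C(F)(F)F)cc(C(F)(F)F)c1` likewise reaches only a limit in this assay, > 50 h. Both shown values rest on the same limit, (the limit of > 50 h in this assay, at which 2 of the 2 values shown sit), so the one measured step, a step that the two limits leave unreadable from compound 1 to compound 2, is not readable in size or direction, and the two limits show only that neither compound fell below it.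

Compound 3 `FC(F)(F)c1cc(S)cc(C(F)(F)F)c1` carries a different group at the same place on the shared core: sulfanyl in place of fluoro on an aromatic carbon. No measured step bears on a sulfanyl group, and the single step shown gives no readable size to lean on. The half-life of compound 3 is therefore estimated with wide uncertainty as 30 h, with a range from 5 h to 50 h, a step expected as an at least 1.6-fold lower number from compound 2 to compound 3 (0.22 log units; that floor lies within the scatter), which may again end at the limit.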

Compound 3, half-life: > 50 h
Compound 3: only a limit was reported (the forecaster's own chance of this, stated with the estimate: 40%); middle value at least 1.6-fold (0.22 log units) away from the limit.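

In this assay compound 3 also reaches only a limit, > 50 h. No step among compound 1, compound 2 and compound 3 can be read in size or direction: the limit of > 50 h in this assay, at which 3 of the 3 values shown sit.

The compounds shown leave open whether the cyano, fluoro and sulfanyl groups differ in half-life at all.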